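The source may hold more compounds than are shown below. What is called first, only, known or untested is meant among the compounds shown, and "the series" means these compounds.

Measured so far in an assay on isolated protein for inhibition of Myeloperoxidase (Homo sapiens), read by fluorescence, with stated times of 10 min, 30 s and 5 min; a higher number here means a weaker inhibitor, a lower number a stronger inhibitor:

compound 1, `Nc1nc(OCc2ccccc2F)c2nn[nH]c2n1`: 78 nM
compound 2, `Nc1nc(OCc2ccccc2Cl)c2nn[nH]c2n1`: 180 nM
compound 3, `Nc1nc(OCc2cccc(F)c2)c2nn[nH]c2n1`: 40 nM

Compound 2 differs from compound 1 by chloro in place of fluoro on an aromatic carbon, and this change gave a 2.3-fold higher number from compound 1 to compound 2 (0.36 log units; beyond the scatter). Compound 3 and compound 1 hold the same atoms joined differently; the difference between the two cores is not broken down here. Compound 3 has the lowest number of the three, but its gap to compound 1 lies within the scatter, so no order between those two is claimed.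

Compound 4, `Nc1nc(OCc2cccc(Cl)c2)c2nn[nH]c2n1`, has not yet been run in this assay. It differs from compound 3 by chloro in place of fluoro on an aromatic carbon. Among the compounds with values here, this is the same kind of change as the one from compound 1 to compound 2, not the same: there the place is ortho to a large group, here meta to a large group. Within the data shown here, only one earlier instance exists, so the expectation rests on it alone.

For compound 4 the expected step is a 2.3-fold higher number from compound 3 to compound 4 (0.35 log units; beyond the scatter), resting on a 2.3-fold higher number from compound 1 to compound 2 (0.36 log units; beyond the scatter). Compound 4 is estimated at 90 nM, with a likely range from 40 nM to 200 nM.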

Compound 4, half-maximal inhibitory concentration: 200 nM
The estimate for compound 4 lay 2.2-fold (0.35 log units) below the measured number; low and high end bracket the measured number.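

In this assay, chloro in place of fluoro, meta to a large group, gives a 5.0-fold higher number from compound 3 to compound 4 (0.70 log units; beyond the scatter). The change moves the number the same way on both cores, and the sizes of the two steps cannot be told apart: the same change on two cores in this assay, a 2.3-fold higher number (0.36 log units; beyond the scatter) from compound 1 to compound 2 and a 5.0-fold higher number (0.70 log units; beyond the scatter) from compound 3 to compound 4, 2.2-fold (0.34 log units) apart, within the scatter of two such steps. Across these two pairs the direction carries over, but two pairs fix no general size for the step and do not show that it would hold on any further core.

The compounds shown leave open how a methoxy, a nitrile or a trifluoromethyl group would read in the same place. They also leave open the effect of an amine or a carboxylic acid there.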